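The compounds below may be only part of what the source reports. "The series", "measured", "known", "first", "only" and "open" are said of these compounds alone.

Compound 2 `CC[C@H](C)[C@H](N)CN(C(=O)[C@@H]1C[C@H]1c1ccncc1)c1ccc(-c2ccccc2)cc1` gives 1500 nM in a functional assay for agonist activity at G protein-coupled receptor 88 (Homo sapiens), read by HTRF and cAMP accumulation; a lower number here means that less compound is needed, a higher number that more compound is needed for the effect. Going by the values given here, only one other number is known in this assay: compound 1 `CC[C@H](C)[C@H](N)CN(C(=O)[C@@H]1C[C@H]1c1ccc(F)cc1F)c1ccc(-c2ccccc2)cc1` gives 1300 nM, and the two lie within the scatter of each other, a 1.2-fold higher number from compound 1 to compound 2 (0.06 log units; within the scatter). Compound 3 `CC[C@H](C)[C@H](N)CN(C(=O)[C@@H]1C[C@H]1c1nc(C)cs1)c1ccc(-c2ccccc2)cc1` differs from compound 2 in one place: 4-methyl-1,3-thiazol-2-yl in place of pyridin-4-yl on a saturated ring carbon. Among the compounds with values here, the one measured step at this position, the ring swap from compound 1 to compound 2, stayed within the scatter. On that basis the step from compound 2 to compound 3 is expected to stay within the scatter as well, no change at the digits printed from compound 2 to compound 3 (within the scatter). Compound 3 is therefore estimated at 1500 nM, with a range of 600 nM to 3800 nM.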

Compound 3, half-maximal effective concentration: 730 nM
Compound 3: middle estimate off by 2.1-fold (0.31 log units), on the high side, and the stated range covers the measured number.
By their numbers in this assay, from the lowest: compounds 3, 1 and 2 (each within the scatter of the next, the first and the last beyond it).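

Going by these compounds alone, on the saturated ring carbon of the three-membered ring, the ring swap can now shift the number: 4-methyl-1,3-thiazol-2-yl in place of pyridin-4-yl gives a 2.1-fold lower number from compound 2 to compound 3 (0.31 log units; beyond the scatter) and is the first step here beyond the scatter, though a modest one. Against the 2,4-difluorophenyl group, the same entering group gives a 1.8-fold lower number from compound 1 to compound 3 (0.25 log units; within the scatter) and so stays within it. Nothing available accounts for this difference. Open, from the compounds shown here alone, is whether the methyl or the thiazole ring carries the step, which the unsubstituted 1,3-thiazol-2-yl group would separate. Also open, going by these compounds, is how a carboxylic acid or an aminomethyl group on the ring would read.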